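Notes on the amide nitrogen change from compound 3 to compound 4

A few compounds are considered here, and "the series" means these few. Any claim that something is new, unique, unknown or untested is made for them only; others in the source may bear on it.

Three compounds have numbers in an assay on HEK293 cells for agonist activity at transient receptor potential cation channel subfamily M member 8 (Homo sapiens), read by fluorescence and calcium flux, with a stated time of 15 min; a higher number here means that more compound is needed for the effect, a lower number that less compound is needed. Compound 1 `CCN(Cc1cccs1)C(=O)c1cc2cc(C)ccc2o1` gives 120 nM in this assay. Compound 2 `CCc1ccc(OCC(=O)N(CC)Cc2cccs2)cc1` gives 67 nM. Compound 3 `Cc1ccc(OCC(=O)N(C)Cc2cccs2)cc1` gives 400 nM, the highest of the three numbers; its gaps to compound 1 and to compound 2 both lie beyond the scatter, so compound 3 needs the most compound of the set for the effect. No two of these compounds differ in one place only, so no single step can be read from them.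

Compound 4 `Cc1ccc(OCC(=O)N(O)Cc2cccs2)cc1` differs from compound 3 in one place: hydroxy in place of methyl on an amide-type nitrogen. For the measured compounds named here, none of the measured compounds carries hydroxy on the amide-type nitrogen; they carry methyl or ethyl there, so the change has no precedent within the set. The step is expected to raise the number by an amount beyond the scatter: a 2.5-fold higher number from compound 3 to compound 4 (0.40 log units; beyond the scatter). Compound 4 is accordingly estimated at 1000 nM, with a range from 250 nM to 4000 nM.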

Compound 4, half-maximal effective concentration: 8000 nM
Compound 4: the middle estimate sits 8.0-fold (0.90 log units) below what was measured; the whole stated range lies below it.
By their numbers in this assay, from the lowest: compounds 2 and 1 (each within the scatter of the next); then compound 3; then compound 4.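

In this assay, this first step that can be read at the amide-type nitrogen is large: hydroxy in place of methyl gives a 20-fold higher number from compound 3 to compound 4 (1.30 log units; beyond the scatter). The earlier compounds shown here carried only methyl or ethyl on this nitrogen and differed in other places too, so they could not show how strongly the number depends on the group there. Here, exchanging one carbon for one oxygen, with one hydrogen-bond donor and one hydrogen-bond acceptor entering, is enough to leave compound 4 with the highest number of the four. No measurement at hand accounts for the size of this step.

A single step cannot separate what hydroxy brings from what leaving methyl takes away. As far as these compounds go, how methoxy, the amide hydrogen or a propyl chain on this nitrogen would compare with methyl on the core of compound 3 remains open.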